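Adding a second bromo to the trifluoromethyl compound

This account rests on a few compounds, and the source may have more. Where it says the series, first, only, none or still open, it means among the compounds named here.

Compound 3 `COc1cc(/C=N/Nc2nc(-c3ccc(C(F)(F)F)cc3)cs2)cc(Br)c1OC` is the weaker of the two compounds with a number in a functional assay on Caco-2 cells (Homo sapiens) for inhibition, read by MTT assay, with a stated time of 48 h; a lower number here means a stronger inhibitor, a higher number a weaker inhibitor: compound 3 gives 65900 nM, while compound 2 `COc1cc(/C=N/Nc2nc(-c3ccc(F)c(F)c3)cs2)c(Br)c(Br)c1OC` gives 22800 nM. Compound 1 `COc1cc(/C=N/Nc2nc(-c3cccc(Br)c3)cs2)c(Br)c(Br)c1OC` returns only a limit of the assay in this assay, > 100000 nM, as noted in the limit of > 100000 nM in this assay, at which 1 of the 3 values shown sits. Within the data shown here, the one step measured with a number, an at least 4.3-fold lower number from compound 1 to compound 2 (0.64 log units; beyond the scatter), changes the aryl group on the shared core and says nothing directly about the change now under review.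

Compound 4 `COc1cc(/C=N/Nc2nc(-c3ccc(C(F)(F)F)cc3)cs2)c(Br)c(Br)c1OC` differs from compound 3 in one place: bromo in place of hydrogen on an aromatic carbon. Among the measured compounds shown here, compounds 1 and 2 already carry the bromo group that compound 3 lacks, so the pair of them brackets what the entering group does, but no measured step isolates it. Compound 3 itself sits between the number of compound 2 and the limit of compound 1 in this assay. The expected step is therefore a 1.1-fold higher number from compound 3 to compound 4 (0.03 log units; within the scatter), with no clear direction beyond the scatter. Compound 4 is estimated at 70000 nM in this assay, within a range from 25000 nM to 200000 nM, and a real chance remains that compound 4 reports only a limit, as compound 1 does.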

Compound 4, half-maximal inhibitory concentration: > 100000 nM
Compound 4: a limit, no number; the forecaster's own chance of this, stated with the estimate: 30%; middle value at least 1.4-fold (0.15 log units) away from the limit.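

In this assay, bromo on the aromatic carbon ortho to a bromo group and para to a methoxy group brings no gain with 4-(trifluoromethyl)phenyl in place: the record is an at least 1.5-fold higher number from compound 3 to compound 4 (0.18 log units; that floor lies within the scatter), so a loss is possible but not established. With both bromo groups present, the aryl group still matters, as shown by an at least 4.3-fold higher number from compound 2 to compound 4 (0.64 log units; beyond the scatter), while the step between compound 1 and compound 4 cannot be read, since both values are limits and not numbers. Among the compounds carrying both bromo groups, only compound 2 gives a number, and compound 1 and compound 4 stop at the same limit: the limit of > 100000 nM in this assay, at which 2 of the 4 values shown sit.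

From the compounds shown here alone, how far compound 4 lies past that limit stays open, and with it the true size of the bromo step from compound 3. Also open, going by these compounds, is whether a hydroxyl, an amine or a methyl on the same aromatic carbon would move the number in either direction, and whether the bromo step would run the same way with 3,4-difluorophenyl in place of 4-(trifluoromethyl)phenyl.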